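Alkyne-linked phenylpropanoic acids: phenyl gives way to hexyl

The compounds below may be only part of what the source reports. "The series", "measured", "known", "first", "only" and "open" are said of these compounds alone.

Compound 1, `O=C(O)CCc1ccc(C#CC2CCCC2)cc1`: 490 nM in a functional assay on 1321-N1 cells for agonist activity at Free fatty acid receptor 1 (Homo sapiens), read by calcium flux, with a stated time of 0.4 s; a higher number here means that more compound is needed for the effect, a lower number that less compound is needed
Compound 2, `O=C(O)CCc1ccc(C#CCc2ccccc2)cc1`: 389 nM in this assay

Of the two numbers shown, compound 2 carries the smaller one, but its nearest neighbour, compound 1, lies within the scatter of repeated measurements, so the two compounds cannot be told apart on these data.

Compound 3, `CCCCCCCC#Cc1ccc(CCC(=O)O)cc1`, differs from compound 2 by hexyl in place of phenyl on a saturated chain carbon bound to a triple-bonded carbon. Among the compounds with values here, no measured pair here shows this change, so its size is not known from the set. Within the data shown here, what the set does show is that the two measured compounds, which differ only in the group at the end of the alkyne, return close numbers in this assay; this is the only guide available. The step of a 1.3-fold lower number from compound 2 to compound 3 (0.11 log units; within the scatter) is therefore expected to be small, not clearly beyond the scatter, with no direction favoured. Compound 3 is expected to give about 300 nM in this assay, within a range from 100 nM to 1000 nM.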

Compound 3, half-maximal effective concentration: 1450 nM
Compound 3: the middle estimate sits 4.8-fold (0.68 log units) below what was measured; the whole stated range lies below it.
By their numbers in this assay, from the lowest: compounds 2 and 1 (each within the scatter of the next); then compound 3.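

In this assay, within the data shown here, hexyl in place of phenyl on a saturated chain carbon bound to a triple-bonded carbon brings a 3.7-fold higher number from compound 2 to compound 3 (0.57 log units; beyond the scatter) and thereby gives the first step in the set that lies beyond the scatter, showing that the number responds to the group held at this place. The two groups match in everything counted here, with the same number of heavy atoms, all of them carbon, no hydrogen-bond donors or acceptors and no net charge, and they part only in that phenyl is a ring and hexyl is not; for this pair, then, an open chain of equal heavy-atom count does not stand in for the ring. Nothing available explains the shift.

From the compounds shown here alone, whether a shorter chain such as butyl or a longer chain such as octyl at this place would stay close to compound 3 or return toward compound 2 remains open. So does the question of whether a saturated ring such as cyclohexyl, or a pyridine ring, would read like phenyl or like hexyl.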